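The source may hold more compounds than are shown below. What is called first, only, known or untested is meant among the compounds shown, and "the series" means these compounds.

Compound 1 (`O=C(CCSc1ccc2c(/C=C/c3ccccn3)n[nH]c2c1)Nc1ccccc1`) 690 nM
Compound 2 (`O=C(CCSc1ccc2c(/C=C/c3ccccn3)n[nH]c2c1)Nc1ccc(F)c(C(F)(F)F)c1`) 610 nM

In an ADME assay on BaF3 cells (Mus musculus) for antiproliferative activity, read by CCK-8 assay, with a stated time of 72 h (on this read-out lower numbers stand for stronger inhibition of growth and higher numbers for weaker inhibition of growth), compound 2 stands at 610 nM and lies within the scatter of compound 1. Compound 3 (`COc1ccc(NC(=O)CCSc2ccc3c(/C=C/c4ccccn4)n[nH]c3c2)cc1C(F)(F)F`) has methoxy in place of fluoro on an aromatic carbon ortho to a trifluoromethyl group. Among the measured compounds shown here, the one measured step that bears on this, a 1.1-fold lower number from compound 1 to compound 2 (0.05 log units; within the scatter), brought in the fluoro and the trifluoromethyl together and stayed within the scatter. No exchange of the fluoro alone has been measured. No step beyond the scatter is therefore expected in this assay here. The estimated step is a 1.1-fold higher number from compound 2 to compound 3 (0.03 log units; within the scatter) and carries no direction beyond the scatter. Compound 3 is estimated at 650 nM with an expected range from 280 nM to 1500 nM.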

Compound 3, concentration for 50% growth inhibition: > 10000 nM
Compound 3 gave a limit, no number; the forecaster's own chance of this, stated with the estimate: 3%; middle value at least 15-fold (1.18 log units) from the limit.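

In this assay, methoxy in place of fluoro on this aromatic carbon, ortho to a trifluoromethyl group and para to a large group, gives an at least 16-fold higher number from compound 2 to compound 3 (1.21 log units; beyond the scatter). The value of compound 3 is a limit of the assay, not a number: the limit of > 10000 nM in this assay, at which 1 of the 3 values shown sits. The earlier step, a 1.1-fold lower number from compound 1 to compound 2 (0.05 log units; within the scatter), gave no sign of such sensitivity, whereas this single exchange separates measurable activity from a limit.

Going by these compounds, how a hydroxy group, a chlorine or an ethoxy group would read at this position stays open. So does the true size of this step.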